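The compounds below may be only part of what the source reports. "The series", "measured", "known", "first", "only" and "open" are said of these compounds alone.

In an ADME assay on L6 cells (Rattus norvegicus) for cytotoxicity, read by resazurin assay, with a stated time of 72 h (a higher number here means a weaker inhibitor, a lower number a stronger inhibitor), compound 3 `COC(c1ccc(Cl)cc1)(c1cccnc1)c1ccccc1Cl` reads 58700 nM while compound 1 `OC(c1ccc(Cl)cc1)(c1ccc(Br)cc1)c1cccnc1` reads 57000 nM and these two numbers lie within the scatter of each other. Compound 2 `OC(c1ccc(Cl)cc1)(c1ncccn1)c1ccccc1Cl` gives only a limit of > 100000 nM and no exact number. The next structure is compound 4 `CC(C)CNC(c1ccc(Cl)cc1)(c1cccnc1)c1ccccc1Cl` and the change from compound 3 is isobutylamino in place of methoxy on a saturated chain carbon bound to three aromatic carbons with isobutylamino in place of methoxy on a saturated chain carbon bound to three aromatic carbons. Among the measured compounds shown here, no measured pair shows what such a swap does, so only a moderate move toward a lower number is expected, and the estimated size is a 2.3-fold lower number from compound 3 to compound 4 (0.37 log units; beyond the scatter) with wide uncertainty. In this assay the estimate for compound 4 is 25000 nM with an expected range from 8000 nM to 70000 nM for now.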

Compound 4, half-maximal inhibitory concentration: 59200 nM
Compound 4: the middle estimate sits 2.4-fold (0.37 log units) below what was measured; low and high end bracket the measured number.
By their numbers in this assay, from the lowest: compounds 1, 3 and 4 (each within the scatter of the next). At a limit, above all of these: compound 2.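

In this assay, among the compounds shown here, this is the first measured swap at this position, and it leaves the number effectively unchanged: a 1.0-fold higher number from compound 3 to compound 4 (0.00 log units; within the scatter). On a saturated chain carbon bound to three aromatic carbons, isobutylamino therefore reads like methoxy, despite bringing more heavy atoms and a hydrogen-bond donor. Only compound 2 stands at a limit, so this flat step is a true reading and is not hidden by that limit: the limit of > 100000 nM in this assay, at which 1 of the 4 values shown sits.

As far as these compounds go, whether a carboxylic acid or a longer chain at this carbon would move the number stays open. One swap also cannot show whether other amines would behave like isobutylamino.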